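The source may hold more compounds than are shown below. What is called first, only, known or untested is meant among the compounds shown, and "the series" means these compounds.

Notes on the series. In a functional assay on CHO-K1 cells for antagonist activity at Orexin receptor type 2 (Homo sapiens), read by FLIPR and calcium flux (a higher number here means a weaker inhibitor, a lower number a stronger inhibitor), compound 1 `CCOC(=O)c1ccccc1C(=O)N1C[C@H](Oc2cc(C#N)ccn2)CC[C@H]1C` gives 21 nM, compound 2 `C[C@@H]1CC[C@@H](Oc2cc(C#N)ccn2)CN1C(=O)c1ccccc1CC(F)(F)F` gives 32 nM and compound 3 `CCc1ccnc(O[C@@H]2CC[C@@H](C)N(C(=O)c3ccccc3-n3nccn3)C2)c1` gives 11 nM; compound 3 sits within the scatter of compound 1 and is separated from compound 2 by a gap beyond the scatter. Compound 4 `COC(=O)c1ccnc(O[C@@H]2CC[C@@H](C)N(C(=O)c3ccccc3-n3nccn3)C2)c1` carries methoxycarbonyl in place of ethyl on an aromatic carbon. Among the compounds with values here, the only single-point step so far, a 1.5-fold higher number from compound 1 to compound 2 (0.18 log units; within the scatter), exchanges an ester for a fluorinated group on the other aromatic ring, so it bears on the present change only loosely; no step touches the substituent on the ring bearing the nitrogen. On that basis the expected outcome for compound 4 is a 1.4-fold higher number from compound 3 to compound 4 (0.13 log units; within the scatter), a change not expected to exceed the scatter. Compound 4 is estimated at 15 nM, within 5 nM to 45 nM.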

Compound 4, half-maximal inhibitory concentration: 22 nM
Estimate against measurement, compound 4: 1.5-fold (0.17 log units) below, within the range that was stated.
By their numbers in this assay, from the lowest: compounds 3, 1, 4 and 2 (each within the scatter of the next, the first and the last beyond it).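

In this assay, within the data shown here, the exchange at the carbon opposite the ring nitrogen gives a 2.0-fold higher number from compound 3 to compound 4 (0.30 log units; within the scatter) and is the first single-place reading at this position. A methoxycarbonyl group, with 4 heavy atoms and 2 hydrogen-bond acceptors, thus stands in place of ethyl, with 2 heavy atoms and no acceptor, without a step beyond the scatter. No measured evidence accompanies this result to explain it.

Open, on these data alone, is how a carboxylic acid, an amine or a longer chain would read at this position. Also open, as far as these compounds go, is whether this reading holds when the other aromatic ring carries the ethoxycarbonyl group of compound 1 instead.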